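A purine step: tosyl retained, chloro replaced by an amine

The source may hold more compounds than are shown below. What is called first, only, known or untested is meant among the compounds shown, and "the series" means these compounds.

The account concerns two measured purines and one yet to be measured. Compound 1 `Cc1ccc(S(=O)(=O)n2cnc3c(Cl)ncnc32)cc1` and compound 2 `C1=CC(CCNc2ncnc3[nH]cnc23)CCC1` were both tested in a functional assay on HCT-116 cells (Homo sapiens) for cytotoxicity, read by sulforhodamine B assay, with a stated time of 72 h; a lower number here means a stronger inhibitor, a higher number a weaker inhibitor. Compound 1 gives 22800 nM in this assay, and compound 2 gives 12900 nM in this assay. Of the two numbers that of compound 1 is the higher, but the gap to compound 2 lies within the usual scatter of repeated measurements, so the two compounds cannot be told apart on these data.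

Compound 3 `Cc1ccc(S(=O)(=O)n2cnc3c(NCCC4C=CCCC4)ncnc32)cc1` is the compound still to be measured. It differs from compound 1 in one place: (2-(cyclohex-2-en-1-yl)ethyl)amino in place of chloro on an aromatic carbon. Among the compounds with values here, no measured pair isolates this change, so its effect can only be guessed from the two numbers at hand. Since compound 2, which carries a related amine on a free core, gives 12900 nM, and compound 1 gives 22800 nM, no step beyond the scatter is expected in this assay, with a slight lean toward a lower number. Compound 3 is therefore estimated at 15000 nM, within a range of 5000 nM to 45000 nM, which amounts to an expected step of a 1.5-fold lower number from compound 1 to compound 3 (0.18 log units; within the scatter).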

Compound 3, half-maximal inhibitory concentration: 8700 nM
Estimate against measurement, compound 3: 1.7-fold (0.24 log units) above, and the stated range covers the measured number.
By their numbers in this assay, from the lowest: compounds 3, 2 and 1 (each within the scatter of the next, the first and the last beyond it).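

With the tosyl group kept in place, exchanging chloro for (2-(cyclohex-2-en-1-yl)ethyl)amino on this aromatic carbon gives, in this assay, a 2.6-fold lower number from compound 1 to compound 3 (0.42 log units; beyond the scatter), a modest step that lies beyond the scatter. Within the data shown here, the earlier compounds could not show this: compound 1 and compound 2 differ in more than one place and could not be told apart, so this is the first change at this position whose size can be read. Nothing at hand bears on why the number is lower, and the finding rests on this single pair.

On these data alone, it remains open which part of the new group goes with the step, as a plain ethylamine or a saturated cyclohexyl ring in place of the cyclohexenyl ring would be needed to separate the amine from the ring and its double bond. The part played by the tosyl group is also unsettled, for in this assay compound 2, without it, gives 12900 nM and compound 3, with it, gives 8700 nM, two values within the scatter of each other.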